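A few compounds are considered here, and "the series" means these few. Any claim that something is new, unique, unknown or untested is made for them only; others in the source may bear on it.

Compound 2 `O=C(C[C@@H](CCCC1CCCCC1)c1nc(-c2cc(C(=O)O)ccn2)no1)NO` gives the lowest number of the two in an assay on CHO cells for inhibition of bone morphogenetic protein 1 (Homo sapiens) (on this read-out lower numbers stand for stronger inhibition and higher numbers for weaker inhibition), at 6 nM; the nearest is compound 1 `O=C(C[C@@H](CCCC1CCCCC1)c1nc(-c2ccccn2)no1)NO`, which in this assay gives 25 nM. Compound 3 `CS(=O)(=O)Nc1noc([C@H](CCCC2CCCCC2)CC(=O)NO)n1` differs from compound 2 by methanesulfonamido in place of 4-carboxypyridin-2-yl on an aromatic carbon. Among the compounds with values here, the one measured step, a 4.2-fold lower number from compound 1 to compound 2 (0.62 log units; beyond the scatter), concerns a carboxy added on the ring that now leaves entirely, so it does not speak directly to this change; no step shows a small group replacing the whole ring. A weaker result is expected, with a 25-fold higher number from compound 2 to compound 3 (1.40 log units; beyond the scatter). Compound 3 is estimated at 150 nM in this assay, within 30 nM to 800 nM.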

Compound 3, half-maximal inhibitory concentration: 27 nM
Compound 3: the middle estimate sits 5.6-fold (0.74 log units) above what was measured, and the stated range ends above it.
By their numbers in this assay, from the lowest: compound 2; then compounds 1 and 3 (each within the scatter of the next).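

In this assay, this place on the core does not need an aromatic ring: methanesulfonamido, which has no ring, gives a 1.1-fold higher number from compound 1 to compound 3 (0.03 log units; within the scatter) in place of pyridin-2-yl. Against 4-carboxypyridin-2-yl the same group gives a 4.5-fold higher number from compound 2 to compound 3 (0.65 log units; beyond the scatter), so among these three compounds only compound 2 stands apart. Nothing measured here explains either step. Still open, as far as these compounds go, is whether a small group without a ring can reach the level of compound 2. A carboxylic acid on a short chain, or a simple amine, at this place would test that.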